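The source may report more compounds than this note shows. Statements on the series, on what has been measured and on what is new or still open speak of the compounds shown alone.

Three stilbene-type members of the series, all on a shared core, have a number in an assay on HepG2 cells for activation of nuclear factor erythroid 2-related factor 2 (Homo sapiens), read by a luciferase reporter, with a stated time of 5 h (a lower number here means that less compound is needed, a higher number that more compound is needed for the effect), so far. Compound 1 `Cc1ccc(/C=C/c2ccc(F)cc2)cc1` gives 1300 nM in this assay. Compound 2 `Cc1ccc(/C=C/c2ccccc2F)cc1` gives 1400 nM in this assay. Compound 3 `COc1ccc(/C=C/c2cccc(F)c2)cc1OC` gives 9500 nM in this assay, the highest number of the three.

Compound 2 therefore stands second highest of the three numbers. Its nearest neighbour is compound 1, whose number sits within the scatter of that of compound 2, so no order between the two can be read. The gap to compound 3 lies beyond the scatter; compound 3 differs from compound 2 in more than one place, so only the two values themselves are compared, not a single step.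

Compound 4 `Fc1ccc(/C=C/c2ccccc2F)cc1` has not yet been measured in this assay. It differs from compound 2 by fluoro in place of methyl on an aromatic carbon. For the measured compounds named here, no single-change step between measured compounds is available to set the size of this move. Compound 1, which carries a fluoro on the other ring, gives a number within the scatter of compound 2, which argues against a large shift. The expectation is a step from compound 2 to compound 4 of a 1.4-fold higher number from compound 2 to compound 4 (0.15 log units; within the scatter), not clearly beyond the scatter. Compound 4 is accordingly estimated at 2000 nM in this assay, with a range from 700 nM to 6000 nM.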

Compound 4, half-maximal effective concentration: 3600 nM
Estimate against measurement, compound 4: 1.8-fold (0.26 log units) below; the range from low to high includes it.
By their numbers in this assay, from the lowest: compounds 1 and 2 (each within the scatter of the next); then compound 4; then compound 3.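

Fluoro in place of methyl on an aromatic carbon, para to a group of 9 heavy atoms, gives the first single-change step in the series: in this assay it is a 2.6-fold higher number from compound 2 to compound 4 (0.41 log units; beyond the scatter), so the number at this position responds to the swap, although neither group brings a hydrogen-bond donor, a hydrogen-bond acceptor or a net charge. The earlier compounds shown here could not show this, since no single-change step joined any of them and the closeness of compound 1 and compound 2 said nothing about this position alone; the step is modest and rests on one pair on one background. No measurement at hand bears on what lies behind this change.

From the compounds shown here alone, whether an amine, a carboxylic acid or a longer chain such as propyl on this same aromatic carbon would move the number further, and in which direction, stays open. Also open, going by these compounds, is whether the step from methyl to fluoro keeps its size on a background carrying other groups, such as the methoxy groups of compound 3.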